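The source may report more compounds than this note shows. Statements on the series, on what has been measured and on what is new or still open speak of the compounds shown alone.

Measured compounds:
compound 1 `C/C(=N\NC(=O)c1ccnnc1)c1ccccc1O` with 6400 nM in a functional assay on HL-60 cells (Homo sapiens) for cytotoxicity, read by MTT assay, with a stated time of 72 h; a higher number here means a weaker inhibitor, a lower number a stronger inhibitor
compound 2 `C/C(=N\NC(=O)c1cccnc1)c1ccccc1O` with 7500 nM in this assay
compound 3 `CC/C(=N\NC(=O)c1ccc(-c2ccccc2)cc1)c1ccccc1O` with 1300 nM in this assay

Among the three numbers, compound 1 gives the second highest. Its nearest neighbour is compound 2, where the step of a 1.2-fold higher number from compound 1 to compound 2 (0.07 log units; within the scatter) lies within the scatter. Compound 3 stands furthest away, with a lower number, but it differs from compound 1 in more than one place, so its two values alone tell nothing about any single change.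

Compound 4 `CC/C(=N\NC(=O)c1ccnnc1)c1ccccc1O` has not yet been measured in this assay. It differs from compound 1 by methyl in place of hydrogen on a saturated chain carbon bound to a carbon with a double bond to nitrogen. Among the compounds with values here, none of the measured steps tests this change on its own: the step from compound 1 to compound 2 alters the group on the carbonyl carbon, not the chain. The lower number of compound 3, which carries the same ethyl chain alongside a different carbonyl substituent, hints at no rise, but that hint is confounded. The expectation for compound 4 is therefore a step of a 1.3-fold lower number from compound 1 to compound 4 (0.11 log units; within the scatter) of small size, not beyond the scatter, and the estimated value for compound 4 is 5000 nM, within a range from 2000 nM to 15000 nM.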

Compound 4, half-maximal inhibitory concentration: 9100 nM
Beside the measured number, compound 4's estimate is 1.8-fold (0.26 log units) below it; the measured number falls inside the stated range.
By their numbers in this assay, from the lowest: compound 3; then compounds 1, 2 and 4 (each within the scatter of the next).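

Within the data shown here, the chain position was tested on its own for the first time in compound 4: in this assay, methyl in place of hydrogen on a saturated chain carbon bound to a carbon with a double bond to nitrogen gives a 1.4-fold higher number from compound 1 to compound 4 (0.15 log units; within the scatter), so with pyridazin-4-yl on the carbonyl carbon this change has no effect that can be told from the scatter. The ethyl chain alone also does not carry the number of compound 3, since compound 3 gives 1300 nM and compound 4, with the same chain, gives 9100 nM. No measurement here explains this result.

As far as these compounds go, whether a longer chain such as propyl, or an amine on the same chain carbon, would give a step beyond the scatter remains open. So does whether methyl in place of hydrogen reads the same with pyridin-3-yl on the carbonyl carbon.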